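Ring Size at the Acyl Carbon of a Naphthoquinone Ester

The source may hold more compounds than are shown below. What is called first, only, known or untested is meant among the compounds shown, and "the series" means these compounds.

Compound 1, `CC(=O)OCCC(=O)O[C@H](CC=C(C)C)C1=CC(=O)c2c(O)ccc(O)c2C1=O`: 17300 nM in a functional assay on HeLa cells (Homo sapiens) for cytotoxicity, read by MTT assay; on this read-out lower numbers stand for stronger inhibition and higher numbers for weaker inhibition. Compound 2, `CCC(C)(O)CC(=O)O[C@H](CC=C(C)C)C1=CC(=O)c2c(O)ccc(O)c2C1=O`: 25200 nM. Compound 3, `CC(C)=CC[C@@H](OC(=O)C1CCCO1)C1=CC(=O)c2c(O)ccc(O)c2C1=O`: 17000 nM.

All three compounds share one core and differ only in the group on the carbonyl carbon of the side chain. Their numbers lie close together: the steps of a 1.5-fold higher number from compound 1 to compound 2 (0.16 log units; within the scatter), a 1.0-fold lower number from compound 1 to compound 3 (0.01 log units; within the scatter) and a 1.5-fold lower number from compound 2 to compound 3 (0.17 log units; within the scatter) all fall within the usual scatter, so compound 3 cannot be set apart from compound 1 or compound 2 on these data.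

Compound 4, `CC(C)=CC[C@@H](OC(=O)C1CCCCO1)C1=CC(=O)c2c(O)ccc(O)c2C1=O`, is not yet measured. It differs from compound 3 in one place: oxan-2-yl in place of oxolan-2-yl on a carbonyl carbon. Going by the values given here, no measured step exchanges one ring for another at this carbonyl carbon; the three steps above only show that quite different groups there leave the read-out unmoved. On that basis the step of no change at the digits printed from compound 3 to compound 4 (within the scatter) is expected to stay within the scatter. Compound 4 is therefore estimated at 17000 nM, with a range from 8000 nM to 36000 nM.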

Compound 4, half-maximal inhibitory concentration: > 100000 nM
Compound 4: a limit, no number; the forecaster's own chance of this, stated with the estimate: 5%; at least 5.8-fold (0.76 log units) between middle value and limit.
By their numbers in this assay, from the lowest: compounds 3, 1 and 2 (each within the scatter of the next). At a limit, above all of these: compound 4.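

Compound 4 stands at a limit of this assay, not at a number: the limit of > 100000 nM in this assay, at which 1 of the 4 values shown sits. The group on this carbonyl carbon had seemed to matter little across 2-acetoxyethyl, 2-hydroxy-2-methylbutyl and oxolan-2-yl, yet a single change of ring, oxan-2-yl in place of oxolan-2-yl, gives an at least 5.8-fold higher number from compound 3 to compound 4 (0.76 log units; beyond the scatter). The oxan-2-yl group also parts from the two open-chain groups, with an at least 5.7-fold higher number from compound 1 to compound 4 (0.76 log units; beyond the scatter) and an at least 3.9-fold higher number from compound 2 to compound 4 (0.59 log units; beyond the scatter), so among these compounds only compound 4 departs from the others.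

The full size of these steps stays open, and nothing shown separates the six-membered ring itself from the ring oxygen as the source of the change. Also open, from the compounds shown here alone, is how a cyclopentyl or cyclohexyl group, or a piperidin-2-yl ring with its amine, would read at this carbonyl carbon.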